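This account rests on a few compounds, and the source may have more. Where it says the series, first, only, none or still open, it means among the compounds named here.

Of the compounds shown here, three sharing one core have so far been read in a physicochemical assay for lipophilicity, read by HPLC, at pH 7.4; a lower number here means a more polar compound, a higher number a more lipophilic compound. Compound 2 (`O=C(O)COc1ccc([C@H]2CC[C@]3(CC2)OOC2(O3)C3CC4CC(C3)CC2C4)cc1`) gives 2.9, the highest of the three numbers. Compound 3 (`O=C(O)COc1ccc([C@H]2CC[C@]3(CC2)OOC2(O3)C3CC4CC(C3)CC2C4)cc1C(=O)O`) gives 1.9, and compound 1 (`O=C(O)COc1ccc([C@H]2CC[C@]3(CC2)OOC2(O3)C3CC4CC2CC(C3)C4O)cc1`) gives 1.7.

Compound 4 (`CS(=O)(=O)NC(=O)COc1ccc([C@H]2CC[C@]3(CC2)OOC2(O3)C3CC4CC(C3)CC2C4)cc1`) is compound 2 with a single change: methanesulfonamido in place of hydroxy on a carbonyl carbon. This is methanesulfonamido in place of hydroxy on a carbonyl carbon, so that carboxy becomes (methylsulfonyl)carbamoyl.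

Going by the values given here, no measured step makes this change, so its size has no direct precedent. Among the compounds with values here, two steps bear on it only indirectly. One is a number 1.20 log units higher from compound 1 to compound 2 (beyond the scatter), with hydrogen in place of hydroxy on a saturated ring carbon. The other is a number 1.00 log units lower from compound 2 to compound 3 (beyond the scatter), with carboxy in place of hydrogen on an aromatic carbon. Both show that one change can move this assay well beyond the scatter. In both, the compound carrying the extra hydroxy or carboxy has the lower number. In compound 4 a hydroxy leaves and methanesulfonamido enters, which gives only a weak guide to direction. A modest rise, smaller than either of those steps, is expected, and the expected step is a number 0.40 log units higher from compound 2 to compound 4 (beyond the scatter). For compound 4 the estimated value is 3.3, with an expected range of 2.6 to 4.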

Compound 4, distribution coefficient: 3
For compound 4 the middle estimate is 0.30 log units above the measured one, within the range that was stated.
By their numbers in this assay, from the lowest: compounds 1 and 3 (each within the scatter of the next); then compounds 2 and 4 (each within the scatter of the next).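

In this assay, methanesulfonamido, with 5 heavy atoms, in place of hydroxy, with 1 heavy atom, on a carbonyl carbon gives a number 0.10 log units higher from compound 2 to compound 4 (within the scatter) and so leaves the reading within the scatter. This position therefore accepts the change of carboxy to (methylsulfonyl)carbamoyl without a shift that can be read here, whereas the earlier single changes at other places moved the number beyond the scatter (a number 1.20 log units higher from compound 1 to compound 2 (beyond the scatter); a number 1.00 log units lower from compound 2 to compound 3 (beyond the scatter)). No measurement available for either group bears on why the number holds at this position.

The compounds shown leave open whether the same replacement holds on the core of compound 1 or compound 3, where the values already stand apart from that of compound 2. They also leave open how other groups on this carbonyl carbon would read, such as a primary amide, a trifluoromethanesulfonamido group, a phenylsulfonamido group or a longer alkylsulfonamido chain, and whether any of them would move this assay beyond the scatter.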